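Aryl ester change from compound 2 to compound 3

The compounds below may be only part of what the source reports. "The series", "measured", "known", "first", "only" and "open" are said of these compounds alone.

Within the data shown here, in a functional assay on MDA-MB-231 cells (Homo sapiens) for antiproliferative activity, read by MTT assay, with a stated time of 72 h (a higher number here means a weaker inhibitor, a lower number a stronger inhibitor), compound 1 (`CC1=CC[C@H]2[C@H](CC[C@]2(C)O)C(C)(C)[C@@H]1CC[C@H]1[C@]2(C)CC[C@H](OC(=O)c3ccc([N+](=O)[O-])cc3)C(C)(C)O[C@H]2CC[C@@]1(C)O`) gives 8900 nM, and compound 2 (`CC1=CC[C@H]2[C@H](CC[C@]2(C)O)C(C)(C)[C@@H]1CC[C@H]1[C@]2(C)CC[C@H](OC(=O)c3cccc([N+](=O)[O-])c3)C(C)(C)O[C@H]2CC[C@@]1(C)O`) gives 34700 nM, the higher of the two numbers so far. Compound 3 (`CC1=CC[C@H]2[C@H](CC[C@]2(C)O)C(C)(C)[C@@H]1CC[C@H]1[C@]2(C)CC[C@H](OC(=O)c3ccc(C(F)(F)F)cc3F)C(C)(C)O[C@H]2CC[C@@]1(C)O`) keeps the shared core and differs from compound 2 only in the ester group: 2-fluoro-4-(trifluoromethyl)phenyl in place of 3-nitrophenyl on a carbonyl carbon. Among the measured compounds shown here, the only measured step that bears on this is a 3.9-fold higher number from compound 1 to compound 2 (0.59 log units; beyond the scatter), modest but beyond the scatter, for 3-nitrophenyl in place of 4-nitrophenyl. For the measured compounds named here, no measured compound carries fluorine, so that step is only a loose guide. Like the 4-nitrophenyl of compound 1, the entering group carries a substituent at 4, so a modest step towards a lower number is expected in this assay. The estimated step is a 2.9-fold lower number from compound 2 to compound 3 (0.46 log units; beyond the scatter). For compound 3 the estimated value is 12000 nM, with an expected range of 4000 nM to 35000 nM.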

Compound 3, half-maximal inhibitory concentration: 36300 nM
For compound 3 the middle estimate is 3.0-fold (0.48 log units) below the measured one; the whole stated range lies below it.
By their numbers in this assay, from the lowest: compound 1; then compounds 2 and 3 (each within the scatter of the next).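

In this assay, replacing 3-nitrophenyl with 2-fluoro-4-(trifluoromethyl)phenyl gives a 1.0-fold higher number from compound 2 to compound 3 (0.02 log units; within the scatter), so these two quite different aryl esters cannot be told apart on this carbonyl carbon. Replacing 4-nitrophenyl with the same group gives a 4.1-fold higher number from compound 1 to compound 3 (0.61 log units; beyond the scatter), so a group at 4 does not by itself give the lower number of compound 1, and compound 3 goes against any such rule. No supporting data accompany these numbers to account for the result.

The compounds shown leave open whether the lower number of compound 1 belongs to the 4-nitrophenyl group alone or would also appear with 4-aminophenyl or 4-cyanophenyl. They also leave open how a plain phenyl ester, or a simple acetate, would read on the shared core.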